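A New Phenyl Group in a Level Series

The compounds below may be only part of what the source reports. "The series", "measured", "known", "first", "only" and "open" are said of these compounds alone.

Compound 1 `COc1cc2ncnc(Nc3ccc(F)c(Cl)c3)c2cc1NC(=O)N/N=C/c1cccc(Cl)c1Cl`: 26100 nM
Compound 2 `COc1ccc(/C=N/NC(=O)Nc2cc3c(Nc4ccc(F)c(Cl)c4)ncnc3cc2OC)cc1`: 21300 nM
Compound 3 `COc1cc2ncnc(Nc3ccc(F)c(Cl)c3)c2cc1NC(=O)N/N=C/c1ccc(OC)c(OC)c1OC`: 31200 nM

All three compounds were tested in a functional assay on HepG2 cells (Homo sapiens) for cytotoxicity, read by MTT assay, with a stated time of 72 h; on this read-out lower numbers stand for stronger inhibition and higher numbers for weaker inhibition. There compound 3, at 31200 nM, stands level with the other two, as neither of its steps leaves the scatter: a 1.2-fold higher number from compound 1 to compound 3 (0.08 log units; within the scatter), and a 1.5-fold higher number from compound 2 to compound 3 (0.17 log units; within the scatter). The remaining step, a 1.2-fold lower number from compound 1 to compound 2 (0.09 log units; within the scatter), is also within the scatter.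

Compound 4 `COc1cc2ncnc(Nc3ccc(F)c(Cl)c3)c2cc1NC(=O)N/N=C/c1ccc(O)c(Br)c1` has not yet been measured. It departs from compound 3 at a single place: 3-bromo-4-hydroxyphenyl in place of 2,3,4-trimethoxyphenyl on a carbon with a double bond to nitrogen. The three measured steps all changed the group at this same place, swapping among 2,3-dichlorophenyl, 4-methoxyphenyl and 2,3,4-trimethoxyphenyl, and none moved this assay beyond the scatter. Among the measured compounds shown here, these steps are the only guide, and no measured compound carries the 3-bromo-4-hydroxyphenyl group, so the expectation remains uncertain. On this evidence, no change beyond the scatter is expected. The expected size is a 1.3-fold lower number from compound 3 to compound 4 (0.11 log units; within the scatter). For compound 4 the estimated value is 24000 nM, with an expected range from 12000 nM to 45000 nM.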

Compound 4, half-maximal inhibitory concentration: 23800 nM
Estimate against measurement, compound 4: 1.0-fold (0.00 log units) above, within the range that was stated.
By their numbers in this assay, from the lowest: compounds 2, 4, 1 and 3 (each within the scatter of the next).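

In this assay the 3-bromo-4-hydroxyphenyl group brings bromine and a hydrogen-bond donor to the carbon with a double bond to nitrogen, where 2,3,4-trimethoxyphenyl has neither, yet the result is only a 1.3-fold lower number from compound 3 to compound 4 (0.12 log units; within the scatter) and stays level with the other two compounds, with a 1.1-fold higher number from compound 2 to compound 4 (0.05 log units; within the scatter) and a 1.1-fold lower number from compound 1 to compound 4 (0.04 log units; within the scatter) as the remaining steps. The earlier compounds had shown this flatness only among dichloro and methoxy substitution on the phenyl ring, so across these four compounds it now extends to a ring bearing a hydroxyl group and a bromine atom. No measurement shown here offers an explanation for this level result.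

Bromine and the hydroxyl group entered together, so the compounds shown cannot separate what either does alone, and a matching change in one could have been offset by the other. They also leave open whether this position stays level when the phenyl ring carries an amine or a carboxylic acid, or when a longer alkyl chain replaces the ring altogether.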